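The source may hold more compounds than are shown below. What is called first, only, known or untested is meant among the compounds shown, and "the series" means these compounds.

Measured so far:
Compound 1, `O=C1c2sccc2N(Cc2ccccc2Br)S(=O)(=O)N1Cc1ccccc1`: > 270000 nM
Compound 2, `O=C1c2sccc2N(Cc2ccc(Br)cc2)S(=O)(=O)N1Cc1ccccc1`: 6600 nM

These two compounds share the same core and differ in one place. In an ADME assay on MT4 cells (Homo sapiens) for cytotoxicity, read by MTT assay, with a stated time of 4 days (on this read-out lower numbers stand for higher toxicity in this test and higher numbers for lower toxicity in this test), compound 2 gives 6600 nM. For compound 1 the result is only a limit, > 270000 nM, and not a number. Among the compounds with values here, compound 2 is therefore the single compound with a measured number here, while the other value sits at the limit of > 270000 nM in this assay, at which 1 of the 2 values shown sits. Within the data shown here, the one measured step, an at least 40-fold lower number from compound 1 to compound 2 (1.61 log units; beyond the scatter), changes 2-bromophenyl to 4-bromophenyl rather than replacing the bromine with something else.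

Compound 3, `N#Cc1ccc(CN2c3ccsc3C(=O)N(Cc3ccccc3)S2(=O)=O)cc1`, is not yet measured. It differs from compound 2 in one place: cyano in place of bromo on an aromatic carbon. Among the measured compounds shown here, no measured step exchanges one group for another on that ring, so the measured step offers no direct guide to the size or direction of this change. Only a modest step is expected. The number for compound 3 is estimated at 15000 nM, with a range from 4000 nM to 80000 nM. That corresponds to an expected step of a 2.3-fold higher number from compound 2 to compound 3 (0.36 log units; beyond the scatter).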

Compound 3, half-maximal cytotoxic concentration: 8500 nM
Beside the measured number, compound 3's estimate is 1.8-fold (0.25 log units) above it, and the stated range covers the measured number.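

In this assay, within the data shown here, the only exchange of one group for another on this ring gives a 1.3-fold higher number from compound 2 to compound 3 (0.11 log units; within the scatter), so bromo and cyano cannot be told apart at this place, para to a large group. Compound 3 also shows that the large step seen with the 4-bromophenyl group is not confined to bromo: an at least 31-fold lower number from compound 1 to compound 3 (1.50 log units; beyond the scatter) stands alongside an at least 40-fold lower number from compound 1 to compound 2 (1.61 log units; beyond the scatter), so both compounds with a group at this place have much lower numbers than compound 1, which stands for higher toxicity in this test. Neither large step has an exact size because the result for compound 1 is a limit and not a number: the limit of > 270000 nM in this assay, at which 1 of the 3 values shown sits.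

The compounds shown leave open whether a different kind of group at this place, such as an amine or a carboxylic acid, would give a number close to those of compound 2 and compound 3. They also leave open whether cyano in place of the bromo of compound 1 would give a result like that of compound 1.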